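Swapping the benzoyl for an acetyl in an acylthiourea

The source may report more compounds than this note shows. Statements on the series, on what has been measured and on what is new or still open speak of the compounds shown alone.

Measured so far in an assay for inhibition of epoxide hydrolase 1 (Homo sapiens), read by fluorescence, using microsomes; on this read-out lower numbers stand for stronger inhibition and higher numbers for weaker inhibition:
Compound 1 `COc1cc([N+](=O)[O-])ccc1NC(=S)NC(=O)c1ccccc1` gives 1650 nM in this assay.
Compound 2 `COc1cc(C)ccc1NC(=S)NC(=O)c1ccccc1` gives 2540 nM in this assay.

Compound 2 has the higher of the two numbers, but the step of a 1.5-fold higher number from compound 1 to compound 2 (0.19 log units; within the scatter) lies within the scatter, so the two compounds cannot be ranked against each other. Compound 3 `COc1cc(C)ccc1NC(=S)NC(C)=O` keeps the core of compound 2 and changes it at one place: methyl in place of phenyl on a carbonyl carbon. Going by the values given here, only one measured step exists, a 1.5-fold higher number from compound 1 to compound 2 (0.19 log units; within the scatter), and it concerns a substituent on the aromatic ring, not the carbonyl side, so nothing measured bears directly on this change. Among the compounds with values here, the loss of a whole ring is a larger structural change than the one step seen, and a step beyond the scatter toward a higher number is the expectation for compound 3, though its direction rests on no measured pair. Compound 3 is therefore estimated at 7000 nM, within 2500 nM to 25000 nM, an expected step of a 2.8-fold higher number from compound 2 to compound 3 (0.44 log units; beyond the scatter).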

Compound 3, half-maximal inhibitory concentration: 1690 nM
Compound 3: the middle estimate sits 4.1-fold (0.62 log units) above what was measured, outside the stated range (below it).
By their numbers in this assay, from the lowest: compounds 1, 3 and 2 (each within the scatter of the next).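

In this assay, putting methyl in place of phenyl on a carbonyl carbon gives a 1.5-fold lower number from compound 2 to compound 3 (0.18 log units; within the scatter), so compound 2 and compound 3 cannot be ranked against each other. Going by these compounds alone, the earlier step concerned only a substituent on the aromatic ring, whereas this one gives the first reading on the carbonyl side. It shows that, with this ring substitution, the phenyl there can be replaced by a single carbon without a difference that can be read in this assay. Nothing measured here explains this result.

Going by these compounds, it remains open whether a longer chain such as ethyl, or an amine, in this place would also stay within the scatter. Also open, on these data alone, is whether methyl in this place would give the same result with the nitro group of compound 1 on the ring.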